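Swapping a fluorophenyl arm for an isobutyl chain

The source may report more compounds than this note shows. Statements on the series, on what has been measured and on what is new or still open speak of the compounds shown alone.

Measured compounds:
compound 1 `O=C(O)c1ccccc1-c1ccc(CCc2ncc(CC3CCOCC3)[nH]2)cc1`: 338 nM
compound 2 `CCCCc1cnc(CCc2ccc(-c3ccccc3C(=O)O)cc2)[nH]1`: 2710 nM
compound 3 `O=C(O)c1ccccc1-c1ccc(CCc2ncc(Cc3cccc(F)c3)[nH]2)cc1`: 159 nM

The three compounds share one core and differ only in the group on a saturated chain carbon bound to an aromatic carbon. In an in vitro functional assay on cells for agonist activity at Bombesin receptor subtype-3 (Homo sapiens), read by luminescence and calcium flux (a higher number here means that more compound is needed for the effect, a lower number that less compound is needed), compound 3 gives the lowest number of the three; the step of a 2.1-fold lower number from compound 1 to compound 3 (0.33 log units; beyond the scatter) is modest, the step of a 17-fold lower number from compound 2 to compound 3 (1.23 log units; beyond the scatter) is large. Compound 4 `CC(C)CCc1cnc(CCc2ccc(-c3ccccc3C(=O)O)cc2)[nH]1` is not yet measured; its change from compound 3 is isobutyl in place of 3-fluorophenyl on a saturated chain carbon bound to an aromatic carbon.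

Among the compounds with values here, two measured steps bear on this. The step of a 17-fold lower number from compound 2 to compound 3 (1.23 log units; beyond the scatter) shows that replacing a plain alkyl chain by the 3-fluorophenyl group lowers the number greatly, and the step of an 8.0-fold higher number from compound 1 to compound 2 (0.90 log units; beyond the scatter) shows that a plain alkyl chain gives a higher number than a saturated ring. Isobutyl is a branched alkyl chain of four carbons, closer to propyl than to either ring. Compound 4 is therefore expected to lie well above compound 3, with a step of about a 9.4-fold higher number from compound 3 to compound 4 (0.97 log units; beyond the scatter), and an estimated value of 1500 nM with a range from 500 nM to 5000 nM.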

Compound 4, half-maximal effective concentration: 119 nM
For compound 4 the middle estimate is 13-fold (1.10 log units) above the measured one; the whole stated range lies above it.
By their numbers in this assay, from the lowest: compounds 4 and 3 (each within the scatter of the next); then compound 1; then compound 2.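

In this assay, isobutyl in place of 3-fluorophenyl makes no difference beyond the scatter (a 1.3-fold lower number from compound 3 to compound 4 (0.13 log units; within the scatter)), so among these compounds an aromatic ring is not needed at this position for a low number. The large step (a 23-fold lower number from compound 2 to compound 4 (1.36 log units; beyond the scatter)) comes from nothing more than methyl in place of hydrogen on a saturated chain carbon bound to two saturated chain carbons, showing that alkyl groups here cannot be treated as one class. Isobutyl also gives a lower number than oxan-4-yl (a 2.8-fold lower number from compound 1 to compound 4 (0.45 log units; beyond the scatter)), so the high number of compound 2 reflects that particular chain, not alkyl chains in general.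

From the compounds shown here alone, how a longer chain, a cyclohexyl ring or an amine would fare at this position remains open. Nothing among the available data accounts for the effect of the added methyl.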